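Ethyl to cyclobutyl on the amide of compound 2

This account rests on a few compounds, and the source may have more. Where it says the series, first, only, none or still open, it means among the compounds named here.

The series rests on one shared core, seen in compound 1 `CCCC(=O)NCCC(=O)c1cc(OC)ccc1N` and compound 2 `CCC(=O)NCCC(=O)c1cc(OC)ccc1N`; in a functional assay for inhibition of kynurenine 3-monooxygenase (Rattus norvegicus), tested at 1 mM (a lower number here means less inhibition, a higher number more inhibition at the concentration tested (going by the name of the read-out)), compound 1 gives "not determined" (no result reported), so no number was reported for it. Going by the values given here, compound 2 is thus the only compound with a number: in this assay compound 2 gives 99.4%, and it stands as the sole reference point, with nothing to compare it against.

The step leads to compound 3 `COc1ccc(N)c(C(=O)CCNC(=O)C2CCC2)c1`, which differs from compound 2 in one place: cyclobutyl in place of ethyl on a carbonyl carbon. The amide nitrogen and the rest of the chain are untouched.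

Among the compounds with values here, since no measured pair shows what such a change does in this assay, the expectation rests on compound 2 alone, whose inhibition already lies close to the top of the read-out. The step from compound 2 to compound 3 is expected to be a number 2.4 percentage points lower from compound 2 to compound 3 (within the scatter), that is, nothing beyond the usual scatter. For compound 3 the estimate in this assay is 97%, with a range from 85% to 100%.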

Compound 3, a percentage reported as inhibition, at one concentration (the size of the read-out at that concentration, not a potency): 92.2%
Compound 3: middle estimate off by 4.8 percentage points, on the high side; the measured number falls inside the stated range.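

Going by these compounds alone, replacing the ethyl with cyclobutyl on a carbonyl carbon gives the first comparison at this position in this assay and amounts to a number 7.2 percentage points lower from compound 2 to compound 3 (within the scatter) in the read-out. A group of 4 heavy atoms carrying a four-membered non-aromatic ring is therefore accommodated in place of one of 2 heavy atoms with no change that can be told from the scatter, so the position is not limited to a small open chain in this pair. Nothing available bears on why the two compounds read alike.

Going by these compounds, it remains open how a phenyl ring, a cyclohexyl ring or a carboxylic acid would read on this carbonyl carbon. A single high concentration also leaves open whether compound 2 and compound 3 would separate at lower concentrations.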